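A few compounds are considered here, and "the series" means these few. Any claim that something is new, unique, unknown or untested is made for them only; others in the source may bear on it.

Compound 1, `CCC1=C(O)c2c(oc(-c3ccc(CC)cc3)cc2=O)C(CC)(CC)C1=O`, was tested in a functional assay on KBVIN cells (Homo sapiens) for antiproliferative activity, read by sulforhodamine B assay, with a stated time of 3 days (a lower number here means that less compound is needed, a higher number that more compound is needed for the effect), where compound 1 gives 0.07 uM. Its companion compound 2, `CCC1=C(O)c2c(oc(-c3ccc(C)c(C)c3)cc2=O)C(CC)(CC)C1=O`, differs from it only in the aryl group on the shared core, and in this assay compound 2 gives 0.71 uM. For the measured compounds named here, the single step joining the two, a 10-fold higher number from compound 1 to compound 2 (1.01 log units; beyond the scatter), is large, so compound 2 stands at the higher of the two numbers so far, with compound 1 as its only and distant neighbour.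

Compound 3, `CCC1=C(O)c2c(oc(-c3cc(C)cc(C)c3)cc2=O)C(CC)(CC)C1=O`, is the next member. Its change from compound 2 is 3,5-dimethylphenyl in place of 3,4-dimethylphenyl on an aromatic carbon. Going by the values given here, only one measured step exists, the one from compound 1 to compound 2, and it concerns a different rearrangement of the same aryl substituents, so it says little directly about moving one methyl group within the ring. That step was large, which shows this position is sensitive, but it gives no direction for the present change. The step from compound 2 to compound 3 is therefore expected to be small, roughly a 1.4-fold higher number from compound 2 to compound 3 (0.15 log units; within the scatter). Compound 3 is accordingly estimated at 1 uM, with a plausible range from 0.3 uM to 3 uM.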

Compound 3, concentration for half-maximal effect: 0.45 uM
For compound 3 the middle estimate is 2.2-fold (0.35 log units) above the measured one; the measured number falls inside the stated range.
By their numbers in this assay, from the lowest: compound 1; then compounds 3 and 2 (each within the scatter of the next).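

In this assay, the change from 3,4-dimethylphenyl to 3,5-dimethylphenyl gives a 1.6-fold lower number from compound 2 to compound 3 (0.20 log units; within the scatter), so for these two groups, moving one methyl group around the aryl ring does not separate the compounds. Against 4-ethylphenyl, 3,5-dimethylphenyl gives a 6.4-fold higher number from compound 1 to compound 3 (0.81 log units; beyond the scatter), which places both dimethylphenyl compounds beyond the scatter from compound 1, so the sensitivity of this position now shows up with two different methyl patterns rather than one. No measurement presented here bears on the reason for this difference.

The three compounds cannot tell whether the low number of compound 1 belongs to the ethyl group itself or to an aryl ring carrying a single substituent, and a 4-methylphenyl or 4-propylphenyl group would be needed to separate those readings. As far as these compounds go, they also carry only carbon substituents on that ring, so it remains open how this position would respond to a methoxy group, an amine or a carboxylic acid in place of the ethyl group of compound 1.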